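The source may hold more compounds than are shown below. What is called first, only, known or untested is meant among the compounds shown, and "the series" means these compounds.

Working notes on the series. Compound 1 `O=C1CSC(c2cccc(F)c2)N1CCN1CCCCC1` and compound 2 `COc1ccccc1C1SCC(=O)N1CCN1CCCCC1` have both been run in an ADME assay on Vero cells (Chlorocebus sabaeus) for cytotoxicity, read by neutral red uptake, tested at 197 ug/mL; a higher number here means a weaker effect of the compound at the concentration tested, a lower number a stronger effect. In this assay compound 1 gives 84%, and compound 2 gives 72%. Of the two numbers compound 1 stands highest; the nearest, compound 2, lies lower by a margin beyond the scatter of repeated measurements. Among the compounds with values here, no step between two measured compounds differing in one place has been worked out, so of this pair only what the two values show can be said.

Compound 3 `O=C1CSC(c2cccc(O)c2)N1CCN1CCCCC1` has not yet been measured in this assay. Relative to compound 1 it carries hydroxy in place of fluoro on an aromatic carbon, the same difference read one bond further out being 3-fluorophenyl to 3-hydroxyphenyl. Within the data shown here, nothing measured so far bears on that exchange. The step of a number 4 percentage points lower from compound 1 to compound 3 (within the scatter) is expected to be small, with no clear direction, most likely within the scatter. For compound 3 the expected value in this assay is therefore 80%, with a range from 62% to 96%.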

Compound 3, a percentage reported as activity, at one concentration (the size of the read-out at that concentration, not a potency): 100%
The estimate for compound 3 lay 20 percentage points below the measured number; the whole stated range lies below it.
By their numbers in this assay, from the lowest: compound 2; then compound 1; then compound 3.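

Hydroxy in place of fluoro on an aromatic carbon, meta to a large group, gives a number 16 percentage points higher from compound 1 to compound 3 (beyond the scatter) in this assay, and this is the only exchange in the series so far that can be read at a single place. The position is therefore not indifferent to what it carries: with the rest of the structure unchanged, this one exchange moves the read-out beyond the scatter and towards a weaker effect of the compound at the concentration tested, with compound 3 at 100%. No measurement of any property of the two groups accompanies this step, so the size and direction of the change stand as an observation only.

From the compounds shown here alone, whether the step is particular to hydroxy remains open, since an amino group or a carboxylic acid at the same place would show whether other groups also move the read-out in this direction. Also open, going by these compounds, is whether the exchange gives a step of similar size when a longer chain joins the shared core to the piperidine-bearing end of the molecule.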